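This account rests on a few compounds, and the source may have more. Where it says the series, first, only, none or still open, it means among the compounds named here.

In a functional assay on MDA-MB-231 cells (Homo sapiens) for cytotoxicity, read by MTT assay, with a stated time of 72 h (on this read-out lower numbers stand for stronger inhibition and higher numbers for weaker inhibition), the series stands thus:

- compound 1 `O=C(CN1CCN(c2nnc(Cc3ccccc3)c3ccccc23)CC1)Nc1ccc(F)c(C(F)(F)F)c1` (760 nM)
- compound 2 `COc1ccc(NC(=O)CN2CCN(c3nnc(Cc4ccccc4)c4ccccc34)CC2)cc1OC` (32200 nM)
- compound 3 `Cc1ccccc1NC(=O)CN1CCN(c2nnc(Cc3ccccc3)c3ccccc23)CC1` (17300 nM)

Compound 3 groups with compound 2 at the high end of the numbers, and a 1.9-fold lower number from compound 2 to compound 3 (0.27 log units; within the scatter) gives them no order. Compound 1 is the most potent of the three (a 23-fold higher number from compound 1 to compound 3 (1.36 log units; beyond the scatter)).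

Compound 4 `O=C(CN1CCN(c2nnc(Cc3ccccc3)c3ccccc23)CC1)Nc1ccc(Br)cc1` carries 4-bromophenyl in place of 2-methylphenyl on an amide-type nitrogen. All three measured steps change the group at this same place. Two are large: a 42-fold higher number from compound 1 to compound 2 (1.63 log units; beyond the scatter) and a 23-fold higher number from compound 1 to compound 3 (1.36 log units; beyond the scatter). Only compound 1 (760 nM) has a halogen-bearing group among the measured compounds, so a move toward its value is expected, though only part of the way. For the measured compounds named here, no measured compound carries bromine, and this single example is thin support. The expected change is a 4.9-fold lower number from compound 3 to compound 4 (0.69 log units; beyond the scatter) and is therefore a moderate to large step toward a lower number, with the wide range reflecting that uncertainty. For compound 4 the estimated value is 3500 nM (expected range 700 nM to 17000 nM).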

Compound 4, half-maximal inhibitory concentration: 12400 nM
The estimate for compound 4 lay 3.5-fold (0.55 log units) below the measured number, within the range that was stated.
By their numbers in this assay, from the lowest: compound 1; then compounds 4, 3 and 2 (each within the scatter of the next, the first and the last beyond it).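

At this place on the amide-type nitrogen, 4-bromophenyl and 2-methylphenyl cannot be told apart in this assay (a 1.4-fold lower number from compound 3 to compound 4 (0.14 log units; within the scatter)), whereas the series does separate 4-bromophenyl from 3,4-dimethoxyphenyl (a 2.6-fold lower number from compound 2 to compound 4 (0.41 log units; beyond the scatter)). A halogen on this aryl group is therefore not enough to reach the level of the 4-fluoro-3-(trifluoromethyl)phenyl group, and compound 1 remains the most potent of the four (a 16-fold higher number from compound 1 to compound 4 (1.21 log units; beyond the scatter)). No measurement is available that bears on the origin of these differences.

The low number of compound 1 still rests on that single group, so its fluorine and trifluoromethyl contributions remain unseparated. Simpler 4-fluorophenyl and 3-(trifluoromethyl)phenyl groups at this place would help to divide them, and the unsubstituted phenyl group would provide a reference.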